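Adding a carboxy group to compound 1

A few compounds are considered here, and "the series" means these few. Any claim that something is new, unique, unknown or untested is made for them only; others in the source may bear on it.

In a physicochemical assay for solubility, at pH 7.4 (on this read-out higher numbers stand for higher solubility and lower numbers for lower solubility), compound 1 `NS(=O)(=O)c1ccc(S(=O)(=O)CCCO)cc1` gives 7200 ug/mL as its value. Two relatives frame that number: compound 2 `NS(=O)(=O)c1ccc(S(=O)(=O)CC(O)CO)cc1` gives 14900 ug/mL and compound 3 `NS(=O)(=O)c1ccc(SCCO)c(F)c1` gives 6000 ug/mL on the same read-out. The numbers of compound 1 and compound 3 lie within the usual scatter of each other, while compound 2 stands higher than compound 1.

Compound 4 `NS(=O)(=O)c1ccc(S(=O)(=O)CCCO)c(C(=O)O)c1` has not been measured yet. It differs from compound 1 by a single change: carboxy in place of hydrogen on an aromatic carbon. In plain terms, a carboxy group takes the place of hydrogen on an aromatic carbon.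

Going by the values given here, only one measured step offers any guide, and a loose one. There is a 2.1-fold higher number from compound 1 to compound 2 (0.32 log units; beyond the scatter) where hydroxy replaces hydrogen on a saturated chain carbon. Among the compounds with values here, that is a different group in a different place, so no measurement yet shows what carboxy does at this position. Taking that modest rise as the only available guide, a modest upward step in this assay is expected, though a result within the scatter would be quite possible. The estimated step is a 1.9-fold higher number from compound 1 to compound 4 (0.29 log units; within the scatter) with wide uncertainty. The expected value for compound 4 is 14000 ug/mL within an estimated range of 6000 ug/mL to 40000 ug/mL.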

Compound 4, solubility: 53000 ug/mL
For compound 4 the middle estimate is 3.8-fold (0.58 log units) below the measured one; the measured number lies above the stated range.
By their numbers in this assay, from the lowest: compounds 3 and 1 (each within the scatter of the next); then compound 2; then compound 4.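

In this assay the aromatic carbon of compound 1 turns out to be a place where a single change moves the number a long way: carboxy in place of hydrogen gives a 7.4-fold higher number from compound 1 to compound 4 (0.87 log units; beyond the scatter) and no loss. The earlier compounds shown here showed only a change on the saturated chain, where hydroxy in place of hydrogen gave a 2.1-fold higher number from compound 1 to compound 2 (0.32 log units; beyond the scatter) and so a smaller step than the one seen on the aromatic carbon. Nothing available gives a measured reason for the size of this new step.

The compounds shown leave open whether the step belongs to carboxy itself or would also appear with another group on the same aromatic carbon, such as an amine, a methyl ester or a primary amide, and whether a longer chain ending in a carboxylic acid would do the same. From the compounds shown here alone, it also stays open whether carboxy on this carbon would give a step of similar size on the core of compound 2, which already carries the extra hydroxy.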